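Methyl on the Aniline Ring: One Step, Two Cores

A few compounds are considered here, and "the series" means these few. Any claim that something is new, unique, unknown or untested is made for them only; others in the source may bear on it.

Measured compounds:
Compound 1, `CN(CC1CCC/C(=C\c2ccc(S(C)(=O)=O)cc2)C1=O)c1ccccc1`, gives 51.1%.
Compound 2, `Cc1ccc(N(C)CC2CCC/C(=C\c3ccc(S(C)(=O)=O)cc3)C2=O)cc1`, gives 31.9%.
Compound 3, `COc1ccc(C2(O)/C(=C/c3ccc(C)cc3)CCCC2CN(C)c2ccccc2)cc1`, gives 17%.

All three were tested in a functional assay on the whole organism (strain Wistar) for inhibition, with Rattus norvegicus as the target, read by paw edema, with stated times of 1 h and 3 h, at a dose of 200 mg/kg by the oral route; on this read-out lower numbers stand for less inhibition and higher numbers for more inhibition at the one dose given (going by the name of the read-out). Compound 1 and compound 2 share one core and differ only by methyl in place of hydrogen on an aromatic carbon. That change is tied to a step of a number 19.2 percentage points lower from compound 1 to compound 2 (beyond the scatter).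

Compound 3 has a different core; the difference between the two cores is not broken down here. Its value is the lowest of the three, and its steps to compound 2 and to compound 1 both lie beyond the usual scatter.

Compound 4, `COc1ccc(C2(O)/C(=C/c3ccc(C)cc3)CCCC2CN(C)c2ccc(C)cc2)cc1`, is not yet measured. It differs from compound 3 by methyl in place of hydrogen on an aromatic carbon. The place of the change is described in the same words for both pairs, on an aromatic carbon of a six-membered aromatic ring of carbon only, para to a large group, so this is the same change seen once already, now made on a second core.

Compound 4 is expected to sit low in this assay, with an estimated step of a number 9 percentage points lower from compound 3 to compound 4 (within the scatter) from compound 3, because the same change gave a number 19.2 percentage points lower from compound 1 to compound 2 (beyond the scatter) and because compound 3 starts from 17%, leaving little room to fall further. The estimate for compound 4 is 8%, expected between 0% and 22%. Going by these compounds, whether the step repeats on a different core is unknown from two pairs alone.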

Compound 4, a percentage reported as inhibition, in the whole organism at one dose (the size of the read-out at that dose, not a potency): 29.8%
For compound 4 the middle estimate is 21.8 percentage points below the measured one, outside the stated range (above it).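

On the second core, methyl in place of hydrogen on the aromatic carbon gave a step of a number 12.8 percentage points higher from compound 3 to compound 4 (beyond the scatter) in this assay. Set beside the result on the first core, the same change does not behave in the same way on the two cores, and the gap between the two steps is larger than chance variation would explain: the same change on two cores in this assay, a number 19.2 percentage points lower (beyond the scatter) from compound 1 to compound 2 and a number 12.8 percentage points higher (beyond the scatter) from compound 3 to compound 4, 32 percentage points apart, beyond the scatter of two such steps. Among the compounds shown here, this shows that, in this series, the size and even the direction of this step cannot simply be carried from one core to another, but it does not show why, as the two cores differ in several places at once and each core offers only one pair.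

The compounds shown leave open which part of the core decides the direction of the step, as no pair here separates those differences one at a time. They also leave open whether another group on the same aromatic carbon, such as a chlorine atom, an ethyl group or a carboxylic acid, would split between the two cores as methyl does.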